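Working notes: compound 2 to compound 3 in HepG2 growth

The source may hold more compounds than are shown below. What is called first, only, known or untested is meant among the compounds shown, and "the series" means these compounds.

Measured so far:
compound 1 `Cc1ccccc1-n1nncc1CN1C(=O)C2(C(C#N)=C(N)Oc3c2c2nc4ccccc4nc2c2ccccc32)c2ccccc21`: > 50000 nM, a limit of the assay
compound 2 `Cc1cccc(-n2nncc2CN2C(=O)C3(C(C#N)=C(N)Oc4c(N)cc5nc6ccccc6nc5c43)c3ccccc32)c1`: > 50000 nM, a limit of the assay

In a functional assay on HepG2 cells (Homo sapiens) for antiproliferative activity, read by MTT assay, with a stated time of 48 h (a higher number here means a weaker inhibitor, a lower number a stronger inhibitor), compound 1 gives > 50000 nM, which is a limit and not a number. Compound 2 gives > 50000 nM in this assay, again a limit rather than a measured number. Compound 2 therefore stands at the limit of > 50000 nM in this assay, at which 2 of the 2 values shown sit, and no ranking between the two measured compounds can be drawn.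

Compound 3 `N#CC1=C(N)Oc2c(N)cc3nc4ccccc4nc3c2C12C(=O)N(Cc1cnnn1-c1ccc([N+](=O)[O-])cc1)c1ccccc12` is the next candidate. Compared with compound 2 the change is 4-nitrophenyl in place of 3-methylphenyl on an aromatic nitrogen.

Among the measured compounds shown here, no step between measured compounds is available, so the size of this change in this assay cannot be read from any neighbouring pair. With both measured values sitting at the limit, the expected step that the limit leaves unreadable from compound 2 to compound 3 is none beyond the scatter, in no stated direction. For compound 3 the estimate in this assay is 60000 nM, with a range from 20000 nM to 200000 nM, most probably reported once more only as a limit.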

Compound 3, half-maximal inhibitory concentration: > 50000 nM
Compound 3: a limit, no number; the forecaster's own chance of this, stated with the estimate: 85%; the middle value is on the limit's open side.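

In this assay compound 3 gives > 50000 nM as a limit of the assay, not a number. Compound 2 also sits at a limit, so no step can be read between compound 2 and compound 3: the limit of > 50000 nM in this assay, at which 3 of the 3 values shown sit. The compounds shown leave open whether any member of this series reaches a measurable value in this assay at all.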